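Benzyloxy in place of cyclopentylmethoxy on a pyrazolopyrimidine acetamide

The compounds below may be only part of what the source reports. "The series", "measured", "known", "first", "only" and "open" are said of these compounds alone.

Measured so far:
- compound 1, `CCN(CC)C(=O)Cc1c(-c2ccc(OC3CCC3)cc2)nn2c(C)cc(C)nc12`: 0.86 nM
- compound 2, `CCN(CC)C(=O)Cc1c(-c2ccc(OCC3CCCC3)cc2)nn2c(C)cc(C)nc12`: 2.1 nM

Both values come from an assay on isolated protein (kidney, strain Wistar) for displacement of a labelled ligand from Translocator protein (Rattus norvegicus), read by scintillation counting, with a stated time of 90 min; on this read-out lower numbers stand for stronger inhibition and higher numbers for weaker inhibition. Compound 2 holds the higher of the two numbers shown; its nearest neighbour is compound 1, and the only single change measured, a 2.4-fold higher number from compound 1 to compound 2 (0.39 log units; beyond the scatter), was a modest rise that went beyond the scatter.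

Compound 3, `CCN(CC)C(=O)Cc1c(-c2ccc(OCc3ccccc3)cc2)nn2c(C)cc(C)nc12`, differs from compound 2 by phenyl in place of cyclopentyl on a saturated chain carbon bound to an oxygen on an aromatic ring. For the measured compounds named here, no measured pair swaps a saturated ring for an aromatic one, so the step from compound 1 to compound 2 bears on it only loosely: it shows that altering the group on the ring oxygen shifts this assay by a modest amount. Since the ring that enters is of similar size to the ring that leaves, the expected step for compound 3 is a 1.4-fold lower number from compound 2 to compound 3 (0.15 log units; within the scatter), small and within the scatter.

The estimate for compound 3 in this assay is therefore 1.5 nM, with a range from 0.5 nM to 5 nM.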

Compound 3, inhibition constant: 0.99 nM
Estimate against measurement, compound 3: 1.5-fold (0.18 log units) above; low and high end bracket the measured number.
By their numbers in this assay, from the lowest: compounds 1 and 3 (each within the scatter of the next); then compound 2.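

In this assay the step of a 2.1-fold lower number from compound 2 to compound 3 (0.33 log units; beyond the scatter) shows that, on the saturated chain carbon bound to the oxygen, an aromatic phenyl ring is not merely accepted but gives a lower number than the saturated cyclopentyl ring. The comparison with the directly attached cyclobutyl ring gives a 1.2-fold higher number from compound 1 to compound 3 (0.06 log units; within the scatter) and stays within the scatter, so the benzyl and cyclobutyl groups cannot be ranked on this oxygen. No independent measurement bears on why the phenyl and cyclopentyl rings differ.

The compounds shown leave open whether a fluorine or a methoxy group on the phenyl ring would keep the number this low, and whether a longer chain carrying that ring would do the same. They also leave open how a pyridyl ring would compare with phenyl.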